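Working notes: from compound 3 to compound 4

The source may report more compounds than this note shows. Statements on the series, on what has been measured and on what is new or still open speak of the compounds shown alone.

Measured in a functional assay on the whole organism with Rattus norvegicus as the target; a lower number here means that less compound is needed, a higher number that more compound is needed for the effect:
- compound 1 `CCOC(=O)C(=O)Nc1nc(-c2cc(Br)no2)cs1` gives > 100 mg/kg as a limit
- compound 2 `CCOCCOC(=O)C(=O)Nc1nc(-c2cc(Br)no2)c(CC)s1` gives 9 mg/kg as a number
- compound 3 `CCOCCOC(=O)C(=O)Nc1nc(-c2cc(OC)no2)cs1` gives 11 mg/kg as a number

For compound 1 the entry > 100 mg/kg is a limit of the assay and not a number. Among the measured compounds shown here, compound 3 at 11 mg/kg and compound 2 at 9 mg/kg lie within the scatter of each other, so compound 3 stands level with the only other compound that has a number.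

Compound 4 `CCOCCOC(=O)C(=O)Nc1nc(-c2cc(-c3c(F)cccc3Cl)no2)cs1` carries 2-chloro-6-fluorophenyl in place of methoxy on an aromatic carbon. For the measured compounds named here, no measured pair isolates this position, so the expectation is loose and is anchored on compound 3 at 11 mg/kg in this assay. On these data alone, a moderate move towards a higher dose is expected, slightly beyond the scatter, and the expected step is a 1.8-fold higher number from compound 3 to compound 4 (0.26 log units; within the scatter) with either direction still open. Compound 4 is estimated at 20 mg/kg (expected range 5 mg/kg to 80 mg/kg).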

Compound 4, dose for half-maximal effect: > 30 mg/kg
Compound 4: only a limit was reported; the forecaster's own chance of this, stated with the estimate: 12%; middle value at least 1.5-fold (0.17 log units) away from the limit.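

In this assay, among the compounds shown here, 2-chloro-6-fluorophenyl in place of methoxy on an aromatic carbon of the five-membered ring gives an at least 2.7-fold higher number from compound 3 to compound 4 (0.43 log units; beyond the scatter), the first step that isolates this position. The position therefore does not accept every group equally: this change, which brings in a six-membered aromatic ring, moves the number towards a higher dose, beyond the scatter. Compound 4 is reported only as a limit, not a number, so the step has a lower bound and no known size: the limit of > 30 mg/kg in this assay, at which 1 of the 4 values shown sits.

The compounds shown leave open whether the shift belongs to the phenyl ring itself or to its chlorine and fluorine, which an unsubstituted phenyl would separate. For the compounds shown here, they also leave open how a small group such as methyl or an amine at this position would compare with methoxy, and no single-place pair yet sets bromo against methoxy.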